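This account rests on a few compounds, and the source may have more. Where it says the series, first, only, none or still open, it means among the compounds named here.

Measured in an ADME assay on a cell-free system (plasma, Homo sapiens) for metabolic stability, read by LC-MS; on this read-out higher numbers stand for a longer-lived compound and lower numbers for a shorter-lived compound:
- compound 1 `CCCCCCOC(=O)c1cccc(-c2cc(C(=O)Nc3ccncc3)ccc2CN)c1`: 0.833 h
- compound 2 `NCc1ccc(C(=O)Nc2ccncc2F)cc1-c1cccc(C(=O)OCC2CCCO2)c1`: < 0.0834 h

Compound 2 gives < 0.0834 h, which is a limit of the assay and not a number. Its true half-life is therefore unresolved, and only compound 1 supplies a number in this assay.

Compound 3 `CCCOC(=O)c1cccc(-c2cc(C(=O)Nc3ccncc3F)ccc2CN)c1` keeps the rest of compound 2 and changes the ester side chain: ethyl in place of oxolan-2-yl on a saturated chain carbon bound to an oxygen next to a carbonyl group. This leaves a propyl chain with no ring.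

Among the compounds with values here, no measured step isolates this change, and compound 1 differs from compound 2 in more than one place. Within the data shown here, compound 1, whose chain there is hexyl, gives 0.833 h, and this is the only guide to a ringless chain, so it is a loose one. An upward move is expected, probably beyond the scatter, with compound 3 still short-lived. The expected step is an at least 2.9-fold higher number from compound 2 to compound 3 (0.47 log units; beyond the scatter). Compound 3 is estimated at 0.25 h, with an expected range of 0.08 h to 0.8 h.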

Compound 3, half-life: 0.317 h
Compound 3: middle estimate off by 1.3-fold (0.10 log units), on the low side, within the range that was stated.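

In this assay, ethyl in place of oxolan-2-yl on a saturated chain carbon bound to an oxygen next to a carbonyl group gives an at least 3.8-fold higher number from compound 2 to compound 3 (0.57 log units; beyond the scatter), the first step read at this position. With the rest of the structure kept, a change at this one place is thus enough to move the half-life beyond the usual scatter, and compound 3 gives the ringless propoxycarbonyl side chain a number on this exact core. Compound 2 carries a limit of the assay and not a number, so the step fixes only the smallest size of the change and leaves its full size unknown: the limit of < 0.0834 h in this assay, at which 1 of the 3 values shown sits.

The step removes the ring and its oxygen together, and the compounds shown do not separate the two, so a cyclopentylmethyl ester, with the ring kept and the ring oxygen gone, would be needed to tell them apart. As far as these compounds go, the effect of chain length on this core also stays open, since compound 1 differs from compound 3 in more than one place, and a butyl or isopropyl ester would give a cleaner comparison with the propyl chain.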